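The source may report more compounds than this note shows. Statements on the series, on what has been measured and on what is new or still open speak of the compounds shown alone.

Measured so far:
compound 1, `CNc1cc(Cl)c(C(N)=O)cn1`, gives 639 nM in an assay on isolated protein for inhibition of Nicotinamide N-methyltransferase (Homo sapiens), read by luminescence, with a stated time of 20 min; a higher number here means a weaker inhibitor, a lower number a stronger inhibitor
compound 2, `CNc1cc(OC)c(C(N)=O)cn1`, gives > 10000 nM in this assay

Compound 1 is the only one of the two with a true number. Compound 2 stands at a limit of this assay, not at a measured number, and that limit is described by the limit of > 10000 nM in this assay, at which 1 of the 2 values shown sits. Among the measured compounds shown here, the single measured step, an at least 15-fold higher number from compound 1 to compound 2 (1.19 log units; beyond the scatter), is large and goes toward weaker inhibition when methoxy replaces chloro on the shared core.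

Compound 3, `CNc1cc(C(F)(F)F)c(C(N)=O)cn1`, differs from compound 2 in one place: trifluoromethyl in place of methoxy on an aromatic carbon. For the measured compounds named here, no measured step involves trifluoromethyl, so nothing here tells how it compares with chloro or methoxy directly. What the measured pair does show is that this position tolerates a small group such as chloro with a measurable number and that methoxy pushes the value past the limit. Compound 3 is therefore expected to fall back inside the measurable range, at an estimated 2000 nM, with a range from 400 nM to 10000 nM. That expectation amounts to an estimated step of an at least 5.0-fold lower number from compound 2 to compound 3 (0.69 log units; beyond the scatter).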

Compound 3, half-maximal inhibitory concentration: > 10000 nM
Compound 3 ended at the assay's limit; the forecaster's own chance of this, stated with the estimate: 25%; middle value at least 5.0-fold (0.69 log units) away from the limit.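

In this assay compound 3 gives > 10000 nM, which is a limit of the assay and not a number. Trifluoromethyl in place of chloro on this aromatic carbon, opposite the ring nitrogen, gives an at least 15-fold higher number from compound 1 to compound 3 (1.19 log units; beyond the scatter), so the loss is not confined to methoxy, and it also appears with a group that has no hydrogen-bond acceptor. Methoxy and trifluoromethyl cannot be ranked against each other, and the step between them cannot be read, because both values are limits: the limit of > 10000 nM in this assay, at which 2 of the 3 values shown sit.

On these data alone, how far past that limit compound 2 and compound 3 really lie remains unknown. The compounds shown also leave open how a bromine, a methyl group or a nitrile at this position would compare with the chloro of compound 1.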